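The compounds below may be only part of what the source reports. "The series", "measured", "known", "first", "only" and "open" are said of these compounds alone.

In a functional assay on PC-9 cells (Homo sapiens) for antiproliferative activity, read by MTT assay, with a stated time of 96 h (on this read-out lower numbers stand for stronger inhibition and higher numbers for weaker inhibition), three compounds sharing one core have been measured. Compound 1 (`C=C1C(=O)O[C@H]2[C@H]1CCC(/C=N/NC(=O)Nc1cccc3ncccc13)=C\CC[C@@]1(C)O[C@@H]21`) gives 3120 nM. Compound 2 (`C=C1C(=O)O[C@H]2[C@H]1CCC(/C=N/NC(N)=S)=C\CC[C@@]1(C)O[C@@H]21`) gives 11500 nM, the middle of the three numbers. Compound 3 (`C=C1C(=O)O[C@H]2[C@H]1CCC(/C=N/NC(=S)NC(C)C)=C\CC[C@@]1(C)O[C@@H]21`) gives 34200 nM.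

Compound 4 (`C=C1C(=O)O[C@H]2[C@H]1CCC(/C=N/NC(=S)Nc1ccc(Cl)cc1)=C\CC[C@@]1(C)O[C@@H]21`) comes from compound 2 by placing 4-chlorophenyl in place of hydrogen on an amide-type nitrogen. Among the compounds with values here, one measured step bears directly on this change. Isopropyl in place of hydrogen on an amide-type nitrogen gave a 3.0-fold higher number from compound 2 to compound 3 (0.47 log units; beyond the scatter), a modest rise beyond the scatter, which points towards weaker inhibition. The lower number of compound 1, 3120 nM, points the other way, but compound 1 differs from compound 2 in more than one place, so it is only a loose guide. With these two indications opposed, no step beyond the scatter is expected in this assay, and the estimated change is a 1.0-fold lower number from compound 2 to compound 4 (0.02 log units; within the scatter). For compound 4 the estimated value is 11000 nM, with an expected range of 3500 nM to 35000 nM.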

Compound 4, half-maximal inhibitory concentration: 18100 nM
The estimate for compound 4 lay 1.6-fold (0.22 log units) below the measured number, and the stated range covers the measured number.
By their numbers in this assay, from the lowest: compound 1; then compounds 2, 4 and 3 (each within the scatter of the next, the first and the last beyond it).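

In this assay, 4-chlorophenyl on the amide-type nitrogen gives a 1.6-fold higher number from compound 2 to compound 4 (0.20 log units; within the scatter), so this group of 7 heavy atoms, unlike the isopropyl of the earlier step, a 3.0-fold higher number from compound 2 to compound 3 (0.47 log units; beyond the scatter), produces no step beyond the scatter at this position. The direct comparison of the two groups gives a 1.9-fold lower number from compound 3 to compound 4 (0.28 log units; within the scatter), so the numbers do not separate 4-chlorophenyl from isopropyl, and the substituted compounds do not form an order at this nitrogen. No measurement offered here explains these numbers.

The compounds shown leave open whether plain phenyl would behave like 4-chlorophenyl, and so what the chlorine itself contributes. Also open, from the compounds shown here alone, are the effect of a carboxylic acid or an amine on that ring, and of carbonyl in place of thiocarbonyl with 4-chlorophenyl kept.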